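Trifluoromethyl in Place of Cyano on the Benzyl Ring

This account rests on a few compounds, and the source may have more. Where it says the series, first, only, none or still open, it means among the compounds named here.

Measured so far:
compound 1 `CN(Cc1nc(C2CCN(Cc3ccccc3Cl)CC2)no1)c1ncc(C(=O)NO)cn1`: 55%
compound 2 `CN(Cc1nc(C2CCN(Cc3ccc(C#N)cc3)CC2)no1)c1ncc(C(=O)NO)cn1`: 38%

In an assay on isolated protein for inhibition of protein deacetylase HDAC6 (Homo sapiens), read by fluorescence, with a stated time of 1 h, tested at 100 nM (a higher number here means more inhibition at the concentration tested (going by the name of the read-out), a lower number less inhibition), compound 2 gives 38%, the lower of the two numbers measured, and compound 1 gives 55%. Compound 3 `CN(Cc1nc(C2CCN(Cc3ccc(C(F)(F)F)cc3)CC2)no1)c1ncc(C(=O)NO)cn1` differs from compound 2 by trifluoromethyl in place of cyano on an aromatic carbon. Among the compounds with values here, the one measured step, a number 17 percentage points lower from compound 1 to compound 2 (beyond the scatter), also alters a group on this aromatic ring and shows that such changes move the number only modestly. Within the data shown here, no measured pair compares cyano with trifluoromethyl, so no direction beyond the scatter is expected. Compound 3 is estimated to give 45%, with a range from 25% to 65%. The expected step of a number 7 percentage points higher from compound 2 to compound 3 (within the scatter) is small.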

Compound 3, a percentage reported as inhibition, at one concentration (the size of the read-out at that concentration, not a potency): 30%
Compound 3: the middle estimate sits 15 percentage points above what was measured, within the range that was stated.
By their numbers in this assay, from the lowest: compounds 3 and 2 (each within the scatter of the next); then compound 1.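

In this assay the swap from cyano to trifluoromethyl on this aromatic carbon gives a number 8 percentage points lower from compound 2 to compound 3 (within the scatter) so these two groups cannot be told apart at this position. Replacing 2-chlorophenyl with 4-(trifluoromethyl)phenyl gives a number 25 percentage points lower from compound 1 to compound 3 (beyond the scatter) and so a second 4-substituted ring, after 4-cyanophenyl, reads beyond the scatter from the 2-chlorophenyl of compound 1. Nothing available explains these numbers. Still open, on these data alone, is whether a 4-chlorophenyl ring would read like compound 1 or like compound 3, and how an amine on the same aromatic carbon would compare.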